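The source may hold more compounds than are shown below. What is called first, only, known or untested is meant among the compounds shown, and "the series" means these compounds.

Measured in a functional assay on brain (Rattus norvegicus, strain Wistar) for inhibition; on this read-out higher numbers stand for weaker inhibition and lower numbers for stronger inhibition:
- Compound 1 `CCCCc1ccc(-c2c(C)[nH]c(=O)n2C2CCCCC2)cc1`: 27100 nM
- Compound 2 `CCCCCCOc1ccc(-c2c(C)[nH]c(=O)n2C)cc1`: 7300 nM
- Compound 3 `Cc1[nH]c(=O)n(C2CCCCC2)c1-c1ccc(OCCC(C)C)cc1`: 7200 nM

Compound 3, at 7200 nM, holds the lowest number of the three, but it cannot be separated from compound 2 at 7300 nM, since the two lie within the scatter of each other. Compound 1 stands clearly higher at 27100 nM.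

Compound 4 `CCCCCCOc1ccc(-c2c(C)[nH]c(=O)n2C2CCCCC2)cc1` differs from compound 3 by butyl in place of isopropyl on a saturated chain carbon, two bonds along the chain from an oxygen on an aromatic ring, or isopentyloxy to hexyloxy. Among the measured compounds shown here, only one measured step bears on this chain: a 3.8-fold lower number from compound 1 to compound 3 (0.58 log units; beyond the scatter), with isopentyloxy in place of butyl on an aromatic carbon. That step changed the chain far more than the present edit does. Though it differs from compound 4 elsewhere, compound 2 already carries hexyloxy and gives 7300 nM. No step beyond the scatter is therefore expected in this assay. The estimated change is a 1.2-fold lower number from compound 3 to compound 4 (0.08 log units; within the scatter). Compound 4 is expected at 6000 nM, with an estimated range of 2500 nM to 14000 nM.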

Compound 4, half-maximal inhibitory concentration: 8500 nM
Beside the measured number, compound 4's estimate is 1.4-fold (0.15 log units) below it, and the stated range covers the measured number.
By their numbers in this assay, from the lowest: compounds 3, 2 and 4 (each within the scatter of the next); then compound 1.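

In this assay, going from isopentyloxy to hexyloxy gives a 1.2-fold higher number from compound 3 to compound 4 (0.07 log units; within the scatter), so the isopropyl and butyl chain ends cannot be told apart on this cyclohexyl compound. Cyclohexyl in place of methyl on the aromatic nitrogen, now seen as a single change with the hexyloxy chain held fixed, gives a 1.2-fold higher number from compound 2 to compound 4 (0.07 log units; within the scatter), which is also no separable change. Hexyloxy in place of butyl on the aromatic carbon gives a 3.2-fold lower number from compound 1 to compound 4 (0.50 log units; beyond the scatter), so two different oxygen-linked chains now stand apart from the butyl of compound 1, the other being the isopentyloxy of compound 3.

As far as these compounds go, whether that step follows the oxygen or the chain length stays open, as does how an octyloxy chain or a terminal amine would read at this position. No supporting measurement is available to explain any of these numbers.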